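A Benzyl Group on the Amine Nitrogen of Compound 1

A few compounds are considered here, and "the series" means these few. Any claim that something is new, unique, unknown or untested is made for them only; others in the source may bear on it.

For the measured compounds named here, compound 1 `CCOC(=O)CNc1nc(Nc2cccc(OC)c2)ncc1[N+](=O)[O-]` is the only member of this set with a measured number: in a functional assay on MCF7 cells (Homo sapiens) for antiproliferative activity, read by MTT assay, with a stated time of 48 h (a higher number here means a weaker inhibitor, a lower number a stronger inhibitor), compound 1 gives 35800 nM. Compound 2 `CCOC(=O)CNc1nc(Nc2ccccc2)ncc1[N+](=O)[O-]` reaches only a limit of the assay, > 100000 nM. Compound 3 `CCOC(=O)CNc1nc(Nc2ccc(OC)cc2)ncc1[N+](=O)[O-]` likewise stops at a limit, > 100000 nM. Accordingly the step of an at least 2.7-fold higher number from compound 1 to compound 2 (0.44 log units; beyond the scatter) and the step of an at least 2.7-fold higher number from compound 1 to compound 3 (0.44 log units; beyond the scatter) both end at the limit of > 100000 nM in this assay, at which 2 of the 3 values shown sit. Compound 4 `CCOC(=O)CN(Cc1ccccc1)c1nc(Nc2cccc(OC)c2)ncc1[N+](=O)[O-]` differs from compound 1 elsewhere: benzyl in place of hydrogen on a nitrogen on an aromatic ring. Going by the values given here, none of the measured steps touches that nitrogen, so they offer no direct guide to direction or size; the only anchor is compound 1 at 35800 nM. For compound 4 the expected step is a 1.1-fold higher number from compound 1 to compound 4 (0.05 log units; within the scatter). Compound 4 is estimated at 40000 nM, with a range from 8000 nM to 150000 nM.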

Compound 4, half-maximal inhibitory concentration: > 100000 nM
Compound 4: a limit, no number; the forecaster's own chance of this, stated with the estimate: 35%; at least 2.5-fold (0.39 log units) between middle value and limit.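

Benzyl in place of hydrogen on a nitrogen on an aromatic ring gives an at least 2.7-fold higher number from compound 1 to compound 4 (0.44 log units; beyond the scatter) in this assay, so this nitrogen, which no earlier step touched, does not tolerate every change. Compound 4 carries a limit and not a number, so the full size of the loss cannot be read: the limit of > 100000 nM in this assay, at which 3 of the 4 values shown sit.

One group cannot separate losing the hydrogen from gaining the benzyl. As far as these compounds go, whether methyl on this nitrogen would still give a measurable number stays open.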